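Notes on the ethyl-to-methyl step in the series

A few compounds are considered here, and "the series" means these few. Any claim that something is new, unique, unknown or untested is made for them only; others in the source may bear on it.

The shared core of compound 1 `Cc1nn(C)c2c(O)ncnc12` carries no aryl group; in an assay on membranes from brain for binding affinity to adenosine receptor A1 (Rattus norvegicus), read by radioligand binding (on this read-out higher numbers stand for weaker inhibition and lower numbers for stronger inhibition), compound 1 gives 20100 nM. Among the compounds with values here, compound 2 `Cc1nn(C)c2c(O)nc(-c3ccncc3)nc12` adds a pyridin-4-yl group, and in this assay compound 2 gives 950 nM; the step of a 21-fold lower number from compound 1 to compound 2 (1.33 log units; beyond the scatter) is the only single-change step among the measured compounds. Compound 3 `CCn1nc(C)c2nc(-c3ccccc3)nc(O)c21` carries a phenyl group and an ethyl on the ring nitrogen; in this assay compound 3 gives 670 nM, which sits within the scatter of compound 2 and far apart from compound 1.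

Compound 4 `Cc1nn(C)c2c(O)nc(-c3ccccc3)nc12` differs from compound 3 by hydrogen in place of methyl on a saturated chain carbon bound to an aromatic nitrogen. Within the data shown here, no measured step addresses this change; compound 2 and compound 3 differ in two places at once and their values sit within the scatter of each other, so the chain alone cannot be read from them. The expected step of a 1.0-fold higher number from compound 3 to compound 4 (0.02 log units; within the scatter) from compound 3 to compound 4 in this assay is therefore none beyond the scatter. Compound 4 is estimated at 700 nM in this assay, with a range from 250 nM to 2000 nM.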

Compound 4, half-maximal inhibitory concentration: 1020 nM
Beside the measured number, compound 4's estimate is 1.5-fold (0.16 log units) below it, within the range that was stated.
By their numbers in this assay, from the lowest: compounds 3, 2 and 4 (each within the scatter of the next); then compound 1.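

In this assay the ethyl-to-methyl change gives a 1.5-fold higher number from compound 3 to compound 4 (0.18 log units; within the scatter) and so, on this phenyl-bearing pair, the length of the chain at this place has no effect that can be told from the scatter. Phenyl in place of pyridin-4-yl gives a 1.1-fold higher number from compound 2 to compound 4 (0.03 log units; within the scatter) and so the two aryl groups cannot be told apart with the methyl compounds. Phenyl in place of hydrogen gives a 20-fold lower number from compound 1 to compound 4 (1.29 log units; beyond the scatter) and, like a 21-fold lower number from compound 1 to compound 2 (1.33 log units; beyond the scatter), this large step shows that the aryl group, in either form, accounts for the distance from compound 1. Nothing available explains why these steps take the sizes they do.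

On these data alone, it stays open whether a longer chain, such as propyl or butyl, would also stay within the scatter at this place. As far as these compounds go, an amine or a carboxylic acid on that chain, or ethyl paired with pyridin-4-yl, also remains untested by these compounds.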